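The source may hold more compounds than are shown below. What is called first, only, known or untested is meant among the compounds shown, and "the series" means these compounds.

In a functional assay on A549 cells (Homo sapiens) for cytotoxicity (a higher number here means a weaker inhibitor, a lower number a stronger inhibitor), compound 2 `Cc1ccc(S(=O)(=O)N2CC(c3ccc(Br)cc3)NC2=O)cc1` gives > 253000 nM, which is a limit and not a number. Compound 1 `Cc1ccc(C2CN(S(=O)(=O)c3ccccc3)C(=O)N2)cc1` gives > 316000 nM, also a limit. Compound 3 `O=C1NC(c2ccc(Br)cc2)CN1S(=O)(=O)c1ccc2c(c1)CCC2`, at 33900 nM, is the only one of the three with a true number. Compound 4 `O=C1NC(c2ccc(Br)cc2)CN1S(=O)(=O)c1ccc(Cl)cc1` takes compound 2 and puts chloro in place of methyl on an aromatic carbon, para to a large group: chloro in place of methyl on an aromatic carbon. Among the compounds with values here, no measured pair isolates this change, so only a small shift toward stronger inhibition is expected, perhaps none beyond the scatter. The expected step is an at least 1.2-fold lower number from compound 2 to compound 4 (0.10 log units; that floor lies within the scatter). For compound 4 the estimated value is 200000 nM, with an expected range from 50000 nM to 400000 nM.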

Compound 4, half-maximal inhibitory concentration: 161000 nM
Compound 4: the middle estimate sits 1.2-fold (0.09 log units) above what was measured, within the range that was stated.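

Within the data shown here, the change from 4-methylphenyl to 4-chlorophenyl gives the one step at this position that can be read in this assay, and it is an at least 1.5-fold lower number from compound 2 to compound 4 (0.19 log units; that floor lies within the scatter). Chloro therefore yields a true number here, but the change is not shown to exceed the scatter. Compound 2 gives only a limit, and the step is a floor because of that limit: the limit of > 253000 nM in this assay, at which 1 of the 4 values shown sits.

The compounds shown leave open how large the true gap is. They also leave open what a methoxy group or an amine would give at this position.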